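Swapping the aryl group on a quinoline urea series

The source may hold more compounds than are shown below. What is called first, only, known or untested is meant among the compounds shown, and "the series" means these compounds.

Compound 3 `COc1cc(NC(C)CCCNC(=O)NNC(=O)Nc2cccc(C(F)(F)F)c2)c2ncccc2c1` gives 4900 nM in a functional assay on HeLa cells (Homo sapiens) for inhibition, read by MTT assay, with a stated time of 72 h; on this read-out lower numbers stand for stronger inhibition and higher numbers for weaker inhibition. Compound 1 `COc1cc(NC(C)CCCNC(=O)NNC(=O)Nc2ccc(Cl)cc2)c2ncccc2c1` carries 4-chlorophenyl in place of 3-(trifluoromethyl)phenyl on an amide-type nitrogen and gives 120000 nM in this assay; this change brings a 24-fold higher number from compound 3 to compound 1 (1.39 log units; beyond the scatter). Compound 2 `COc1cc(NC(C)CCCNC(=O)Nc2cccc(C(F)(F)F)c2)c2ncccc2c1`, in which the semicarbazide link is shortened to a single urea, gives 14000 nM in this assay; from compound 1 to compound 2 the figure moves by an 8.6-fold lower number from compound 1 to compound 2 (0.93 log units; beyond the scatter). The difference between the cores of compound 2 and compound 3 is not broken down here. Compound 4 `COc1cc(NC(C)CCCNC(=O)Nc2ccc(Cl)cc2)c2ncccc2c1` has not yet been measured; it differs from compound 2 by 4-chlorophenyl in place of 3-(trifluoromethyl)phenyl on an amide-type nitrogen, the same change as from compound 3 to compound 1, at a place described in the same words. On that single precedent a rise in the number is expected, though the differing core leaves the size uncertain, so compound 4 is estimated at a 10-fold higher number from compound 2 to compound 4 (1.00 log units; beyond the scatter) in this assay. Compound 4 is therefore expected to give about 140000 nM, with a likely span from 40000 nM to 500000 nM.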

Compound 4, half-maximal inhibitory concentration: 18000 nM
Estimate against measurement, compound 4: 7.8-fold (0.89 log units) above; the measured number lies below the stated range.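

The swap of 3-(trifluoromethyl)phenyl for 4-chlorophenyl on an amide-type nitrogen does not carry over with the same size from one core to the other in this assay: the same change on two cores in this assay, a 24-fold higher number (1.39 log units; beyond the scatter) from compound 3 to compound 1 and a 1.3-fold higher number (0.11 log units; within the scatter) from compound 2 to compound 4, 19-fold (1.28 log units) apart, beyond the scatter of two such steps. Among the compounds shown here, with the single urea link the swap gives a 1.3-fold higher number from compound 2 to compound 4 (0.11 log units; within the scatter), so the large rise belongs only to the pair with the longer semicarbazide link, and replacing ((4-chlorophenyl)carbamoyl)amino with 4-chlorophenyl gives a 6.7-fold lower number from compound 1 to compound 4 (0.82 log units; beyond the scatter). With a single pair on each core, this shows that the size of the step depends on the core among these four compounds, but it does not show why, nor what the swap would do on any further core.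

The compounds shown leave open how the two links compare when the aryl group carries an amine or a carboxylic acid. They also leave open whether a longer chain in the link would bring the step back towards either of the two seen here.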